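A few compounds are considered here, and "the series" means these few. Any claim that something is new, unique, unknown or untested is made for them only; others in the source may bear on it.

Measured so far in a functional assay on Mahlavu cells (Homo sapiens) for antiproliferative activity, read by sulforhodamine B assay, with a stated time of 72 h; a lower number here means a stronger inhibitor, a higher number a weaker inhibitor:
- compound 1 `N#Cc1cccc(COc2ccc(-c3cc(CN4CCN(Cc5ccc(C(F)(F)F)cc5)CC4)no3)cc2)c1`: 10600 nM
- compound 2 `COc1cc(COc2ccc(-c3cc(CN4CCN(Cc5ccc(C(F)(F)F)cc5)CC4)no3)cc2)cc(OC)c1`: 4300 nM

Compound 1 stands at the highest of the two numbers in this assay; the nearest is compound 2, reached by a 2.5-fold lower number from compound 1 to compound 2 (0.39 log units; beyond the scatter), a change at the saturated chain carbon bound to the aromatic oxygen.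

Compound 3 `N#Cc1cccc(COc2ccc(-c3cc(CN4CCN(c5ccc(C(F)(F)F)cc5)CC4)no3)cc2)c1` differs from compound 1 by 4-(trifluoromethyl)phenyl in place of 4-(trifluoromethyl)benzyl on an amine nitrogen in a ring. Within the data shown here, the one measured step alters a different part of the shared core, the aryl on the ether chain, and says nothing about the group on the ring nitrogen. Among the measured compounds shown here, no measured pair varies that position, so there is no basis for expecting a step beyond the scatter in this assay; the working assumption is that compound 3 lands near compound 1.

The estimate for compound 3 in this assay is therefore 10000 nM, within 3500 nM to 30000 nM, which corresponds to an expected 1.1-fold lower number from compound 1 to compound 3 (0.03 log units; within the scatter).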

Compound 3, half-maximal inhibitory concentration: 2700 nM
Beside the measured number, compound 3's estimate is 3.7-fold (0.57 log units) above it; the whole stated range lies above it.
By their numbers in this assay, from the lowest: compounds 3 and 2 (each within the scatter of the next); then compound 1.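

The group on the amine nitrogen in the ring is a second position that changes the number in this assay, alongside the aryl on the ether chain: with the 3-cyanophenyl group held constant, 4-(trifluoromethyl)phenyl in place of 4-(trifluoromethyl)benzyl gives a 3.9-fold lower number from compound 1 to compound 3 (0.59 log units; beyond the scatter). The change takes the benzyl chain carbon out of the group, with the trifluoromethyl and the aromatic ring both retained, so the lower number comes with the loss of the benzyl chain carbon alone. No measurement shown explains why this step lowers the number.

Open, as far as these compounds go, is whether a longer chain on this nitrogen, such as 2-phenylethyl, or a chlorine in place of the trifluoromethyl, would shift the number further. Also open, from the compounds shown here alone, is whether the 3,5-dimethoxyphenyl and 4-(trifluoromethyl)phenyl changes would add up within one compound.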